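A furan-to-benzyl swap at the chain end

The source may report more compounds than this note shows. Statements on the series, on what has been measured and on what is new or still open speak of the compounds shown alone.

Among the compounds with values here, compound 2 `COc1ccccc1Oc1ccc2c(NCCCNCc3ccco3)ccnc2c1` is one of three compounds measured in an ADME assay on HepG2 cells (Homo sapiens) for cytotoxicity, read by luminescence, CellTiter-Glo and ATP content, with a stated time of 72 h; a lower number here means that less compound is needed, a higher number that more compound is needed for the effect. In this assay compound 2 gives 6500 nM. Compound 1 `Fc1ccc(Oc2ccc3c(NCCCNCc4ccco4)ccnc3c2)cc1` gives 16000 nM, and compound 3 `Fc1ccc(Cc2ccc3c(NCCCNCc4ccco4)ccnc3c2)c(Cl)c1` gives 5730 nM. Compound 2 thus stands second highest of the three numbers: its step to compound 3, a 1.1-fold lower number from compound 2 to compound 3 (0.05 log units; within the scatter), is too small to separate the two, while the step of a 2.5-fold lower number from compound 1 to compound 2 (0.39 log units; beyond the scatter) sets compound 2 clearly apart from compound 1.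

Compound 4 `COc1ccc(F)cc1CNCCCNc1ccnc2cc(Oc3ccccc3OC)ccc12` has not been measured. It differs from compound 2 in a single place: 5-fluoro-2-methoxyphenyl in place of furan-2-yl on a saturated chain carbon bound to an amine nitrogen. The change sits on a saturated chain carbon bound to an amine nitrogen.

Within the data shown here, none of the measured steps concerns this part of the molecule. The steps of a 2.5-fold lower number from compound 1 to compound 2 (0.39 log units; beyond the scatter), a 2.8-fold lower number from compound 1 to compound 3 (0.45 log units; beyond the scatter) and a 1.1-fold lower number from compound 2 to compound 3 (0.05 log units; within the scatter) all alter the group on the aromatic carbon of the shared core and leave the furan-2-yl untouched. Among the measured compounds shown here, they show only that changes elsewhere shift this assay by modest amounts at most. For the measured compounds named here, with no direct precedent, the expected step is no change at the digits printed from compound 2 to compound 4 (within the scatter), which is essentially none beyond the scatter. Compound 4 is therefore estimated at 6500 nM, with an expected range from 2800 nM to 15000 nM.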

Compound 4, half-maximal effective concentration: 6400 nM
The estimate for compound 4 lay 1.0-fold (0.01 log units) above the measured number; low and high end bracket the measured number.
By their numbers in this assay, from the lowest: compounds 3, 4 and 2 (each within the scatter of the next); then compound 1.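

Within the data shown here, the earlier steps all altered the group on the aromatic carbon of the shared core, so this is the first step at the saturated chain carbon bound to an amine nitrogen, and in this assay it reads a 1.0-fold lower number from compound 2 to compound 4 (0.01 log units; within the scatter) as the only difference between the pair. The swap replaces furan-2-yl, a five-membered aromatic ring with 5 heavy atoms, by 5-fluoro-2-methoxyphenyl, a six-membered ring of carbon only with 9 heavy atoms, and this read-out does not separate the two compounds, although the ring type and the heavy-atom count both differ. No data are available that could explain why the two compounds read alike.

On these data alone, this is a single pair, so it remains open whether the same swap would read alike on the core of compound 1, which carries the 4-fluorophenoxy group, or on the core of compound 3, which carries the 2-chloro-4-fluorobenzyl group. As far as these compounds go, it also remains open how this assay would respond at the same place to a different end group, such as an unsubstituted phenyl, a pyridine ring or a carboxylic acid.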